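The source may hold more compounds than are shown below. What is called first, only, known or untested is meant among the compounds shown, and "the series" means these compounds.

Compound 2 `CCOC(=O)CCCCCOc1ccc(C=O)cc1` carries a formyl group on its aromatic ring. In an ADME assay on HepG2 cells (Homo sapiens) for cytotoxicity, read by CellTiter-Glo and resazurin assay, with a stated time of 72 h (a lower number here means that less compound is needed, a higher number that more compound is needed for the effect), compound 2 gives > 26000 nM, which is a limit of the assay and not a number. Its close relative compound 1 `CCOC(=O)CCCCCOc1ccc(CNC(C)C)cc1` differs only in the group on that aromatic carbon. In this assay compound 1 gives > 26000 nM, again a limit. The step that the two limits leave unreadable from compound 1 to compound 2 therefore cannot be read, since both values sit at the limit of > 26000 nM in this assay, at which 2 of the 2 values shown sit. The new compound 3 `CCOC(=O)CCCCCOc1ccc(C(O)O)cc1` arises from compound 2 by the change (dihydroxymethyl in place of formyl on an aromatic carbon). Among the compounds with values here, only one measured step bears on this position, and its size is hidden behind the two limits, so no direction beyond the scatter can be inferred for compound 3. Compound 3 is expected to stand at the limit as well, estimated at 30000 nM within 15000 nM to 70000 nM. The expected step is a step that the limit leaves unreadable from compound 2 to compound 3, which is likely to remain unresolved.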

Compound 3, half-maximal effective concentration: > 27100 nM
Compound 3: a limit, no number (the forecaster's own chance of this, stated with the estimate: 85%); the middle value is on the limit's open side.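

Within the data shown here, compound 3 gives > 27100 nM in this assay, a limit of the assay and not a number, so no step from compound 1 or compound 2 to compound 3 can be read. The compounds shown leave open whether the group on that aromatic carbon makes any difference to the value.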